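The source may hold more compounds than are shown below. What is called first, only, known or untested is meant among the compounds shown, and "the series" means these compounds.

Compound 1 `C=C1C(=O)Oc2cc(OC)ccc2C1CCCC` in a functional assay on HL-60 cells (Homo sapiens) for cytotoxicity, read by MTT assay, with a stated time of 48 h; a lower number here means a stronger inhibitor, a higher number a weaker inhibitor: 5400 nM
Compound 2 `C=C1C(=O)Oc2cc(OC)ccc2C1C(C)C` in this assay: 560 nM

Compound 2 stands at the lower of the two numbers in this assay, reached by a 9.6-fold lower number from compound 1 to compound 2 (0.98 log units; beyond the scatter). Compound 3 `C=CC1C(=C)C(=O)Oc2cc(OC)ccc21` differs from compound 2 by vinyl in place of isopropyl on a saturated ring carbon, again on a saturated ring carbon. Among the measured compounds shown here, only that one measured step bears on this change, and it ran in favour of the smaller group. Because a 9.6-fold lower number from compound 1 to compound 2 (0.98 log units; beyond the scatter) was a modest fall, a further modest fall is expected for compound 3. Compound 3 is thus estimated at 400 nM, within 100 nM to 1600 nM, an expected step of a 1.4-fold lower number from compound 2 to compound 3 (0.15 log units; within the scatter).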

Compound 3, half-maximal inhibitory concentration: 51700 nM
Estimate against measurement, compound 3: 130-fold (2.11 log units) below; the measured number lies above the stated range.
By their numbers in this assay, from the lowest: compound 2; then compound 1; then compound 3.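

Replacing isopropyl with vinyl gives a 92-fold higher number from compound 2 to compound 3 (1.97 log units; beyond the scatter), and replacing butyl with vinyl gives a 9.6-fold higher number from compound 1 to compound 3 (0.98 log units; beyond the scatter). At this saturated ring carbon, then, the number does not simply fall as the group gets smaller: in this assay, isopropyl gives the lowest number and vinyl the highest. Nothing available explains this reversal. Going by these compounds, it remains open whether the double bond of vinyl or its shorter length goes with the higher number. An ethyl group on this carbon would separate the two, while a cyclopropyl group would test another small carbon group.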